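The source may hold more compounds than are shown below. What is called first, only, known or untested is meant among the compounds shown, and "the series" means these compounds.

Compound 1 `Cc1ccc(N2C(=O)C/C(=C\c3cccc(C(=O)Nc4cccc(F)c4)c3)C2=O)cc1`: 96900 nM
Compound 2 `CCc1cccc(NC(=O)c2cccc(/C=C3\CC(=O)N(Cc4ccccc4)C3=O)c2)c1`: 91500 nM
Compound 3 `Cc1ccc(NC(=O)c2cccc(/C=C3\CC(=O)N(c4ccccc4)C3=O)c2)cc1C`: > 100000 nM

In an ADME assay on SW480 cells (Homo sapiens) for cytotoxicity, read by MTT assay, with a stated time of 72 h (a lower number here means a stronger inhibitor, a higher number a weaker inhibitor), compound 3 gives only a limit of the assay, > 100000 nM, and not a number. It sits at the limit of > 100000 nM in this assay, at which 1 of the 3 values shown sits. Compound 1 and compound 2 give numbers, and those numbers lie close to that limit. Compound 4 `COc1ccc(NC(=O)c2cccc(/C=C3\CC(=O)N(c4ccccc4)C3=O)c2)c(C)c1` differs from compound 3 in one place: 4-methoxy-2-methylphenyl in place of 3,4-dimethylphenyl on an amide-type nitrogen. Among the compounds with values here, no measured pair shows how such an exchange shifts the read-out in this assay, so for compound 4 no step beyond the scatter is expected in either direction, and the result may again come back as a limit. Compound 4 is therefore expected at about 100000 nM, within 45000 nM to 220000 nM, an expected step of a number no higher from compound 3 to compound 4 (the limit leaves the size open).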

Compound 4, half-maximal inhibitory concentration: > 100000 nM
Compound 4: a limit, no number; the forecaster's own chance of this, stated with the estimate: 55%; the middle value sits exactly at the limit.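

Compound 3 and compound 4 each return only a limit of the assay in this assay, so no step can be read between them. The compounds shown leave open how 4-methoxy-2-methylphenyl in place of 3,4-dimethylphenyl on an amide-type nitrogen shifts the read-out.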